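Phenyl to carbamoyl on the ring nitrogen: compound 4

A few compounds are considered here, and "the series" means these few. Any claim that something is new, unique, unknown or untested is made for them only; others in the source may bear on it.

Measured so far in a functional assay on G-361 cells (Homo sapiens) for cytotoxicity, read by MTT assay, with a stated time of 3 days; on this read-out lower numbers stand for stronger inhibition and higher numbers for weaker inhibition:
compound 1, `N#Cc1c(NN)nc(SCc2nc3ccccc3[nH]2)nc1-c1ccccc1`: 14.7 nM
compound 2, `N#Cc1c(Nc2ccccc2)nc(SCc2nc3ccccc3[nH]2)nc1-c1ccccc1`: 2.4 nM
compound 3, `N#Cc1c(Nc2nccs2)nc(SCc2nc3ccccc3[nH]2)nc1-c1ccccc1`: 11.9 nM

Compound 2 gives the lowest number of the three, and its distance to each of the others is beyond the scatter: a 6.1-fold lower number from compound 1 to compound 2 (0.79 log units; beyond the scatter) and a 5.0-fold higher number from compound 2 to compound 3 (0.70 log units; beyond the scatter). Compound 1 and compound 3 sit close together, since a 1.2-fold lower number from compound 1 to compound 3 (0.09 log units; within the scatter).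

Compound 4, `N#Cc1c(NC(N)=O)nc(SCc2nc3ccccc3[nH]2)nc1-c1ccccc1`, is not yet measured. It differs from compound 2 in one place: carbamoyl in place of phenyl on a nitrogen on an aromatic ring. Among the compounds with values here, the steps that bear on this are the two that leave the phenyl of compound 2: a 6.1-fold lower number from compound 1 to compound 2 (0.79 log units; beyond the scatter) shows what phenyl added over amino, and a 5.0-fold higher number from compound 2 to compound 3 (0.70 log units; beyond the scatter) shows what was lost on going to a thiazolyl. Both groups that replaced phenyl gave a modest rise, and the counts for carbamoyl (no ring, one donor, one acceptor) resemble amino more than phenyl. A modest upward step is therefore expected, with a 5.0-fold higher number from compound 2 to compound 4 (0.70 log units; beyond the scatter) as the estimated size. Compound 4 is estimated at 12 nM, with a range from 4 nM to 40 nM; only compound 1 and compound 3 support this, so the range is wide.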

Compound 4, half-maximal inhibitory concentration: 2.55 nM
Compound 4: the middle estimate sits 4.7-fold (0.67 log units) above what was measured; measured number below the stated range.
By their numbers in this assay, from the lowest: compounds 2 and 4 (each within the scatter of the next); then compounds 3 and 1 (each within the scatter of the next).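

In this assay, the step of a 1.1-fold higher number from compound 2 to compound 4 (0.03 log units; within the scatter) shows that an aromatic ring on this nitrogen is not required for a number in the range of compound 2, since the anilino to ureido change leaves the read-out within the scatter. The other two steps, a 4.7-fold lower number from compound 3 to compound 4 (0.67 log units; beyond the scatter) and a 5.8-fold lower number from compound 1 to compound 4 (0.76 log units; beyond the scatter), are both beyond the scatter, which places carbamoyl with phenyl and apart from 1,3-thiazol-2-yl and amino. The presence of a ring therefore does not sort this set: phenyl and 1,3-thiazol-2-yl both carry one but fall on opposite sides, and carbamoyl and amino both lack one and also fall on opposite sides, and nothing measured here accounts for that split.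

On these data alone, it remains open which part of the carbamoyl group matters, and acetyl or methylcarbamoyl on the same nitrogen would test the role of its terminal amine. As far as these compounds go, whether phenyl and carbamoyl stay level in other cell lines, or with a different group in place of the phenyl on the shared core, also remains open.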